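A few compounds are considered here, and "the series" means these few. Any claim that something is new, unique, unknown or untested is made for them only; others in the source may bear on it.

Three compounds have been measured in an assay on isolated protein for inhibition of DNA topoisomerase 1 (Homo sapiens), tested at 100 uM; a lower number here means a weaker effect, a higher number a stronger effect of the compound at the concentration tested:

compound 1, `COc1ccc(C(=O)/C=C/c2ccc(F)cc2)c(O)c1`: 81.2%
compound 2, `COc1cc(O)ccc1/C=C/C(=O)c1ccc(NC(C)=O)cc1`: 100%
compound 3, `COc1ccc(/C=C/C(=O)c2ccc(O)cc2O)cc1Br`: 73.2%

Compound 2 stands highest of the three numbers. Its nearest neighbour is compound 1, whose reading of 81.2% lies lower by a margin beyond the scatter, and the furthest is compound 3, whose reading of 73.2% lies lower still, also beyond the scatter. Among the compounds with values here, the three structures differ in more than one place, so no single step between measured compounds can be isolated; their numbers show only that each is a strong inhibitor at the concentration tested.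

The next compound, compound 4, `COc1cc(O)ccc1/C=C/C(=O)c1ccc(F)cc1`, keeps everything of compound 2 except one group: fluoro in place of acetamido on an aromatic carbon. Within the data shown here, no measured pair isolates this exchange. Compound 1 also carries a fluoro group and gives 81.2% in this assay, which hints that a fluoro-bearing compound of this set can still inhibit strongly while falling short of compound 2. A downward step of moderate size, beyond the scatter, is therefore expected a number 20 percentage points lower from compound 2 to compound 4 (beyond the scatter). Compound 4 is estimated to give 80% in this assay, between 58% and 100%.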

Compound 4, a percentage reported as inhibition, at one concentration (the size of the read-out at that concentration, not a potency): 95.8%
The estimate for compound 4 lay 15.8 percentage points below the measured number; the measured number falls inside the stated range.
By their numbers in this assay, from the lowest: compounds 3 and 1 (each within the scatter of the next); then compounds 4 and 2 (each within the scatter of the next).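

In this assay, fluoro in place of acetamido on an aromatic carbon, para to a large group, gives a number 4.2 percentage points lower from compound 2 to compound 4 (within the scatter), the first exchange in a single place among the compounds shown. At the concentration tested, this position therefore accepts the loss of the acetamido group, with its hydrogen-bond donor and acceptor, and the arrival of a single fluorine without a change that can be told from the scatter. Nothing measured here bears on why compound 2 and compound 4 read alike.

As far as these compounds go, whether the same holds for other groups at this place, such as an amine or a carboxylic acid, stays open, and so does whether the two compounds would still read alike at a lower concentration, since one concentration gives no potency. From the compounds shown here alone, the effect of this exchange on the other substitution patterns also remains unknown, as compound 1 and compound 3 differ from compound 4 in more than one place and offer no comparison.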